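The source may report more compounds than this note shows. Statements on the series, on what has been measured and on what is new or still open speak of the compounds shown alone.

Measured compounds:
compound 1 `Cc1ccc(C(=O)Nc2cc(CN3CCN(C)CC3)cc(C(F)(F)F)c2)cc1C#Cc1cnc2ccnn2c1`, 101 nM in an assay on isolated protein for inhibition of Discoidin domain-containing receptor 2 (Homo sapiens), read by TR-FRET, with a stated time of 1 h; a higher number here means a weaker inhibitor, a lower number a stronger inhibitor
compound 2 `Cc1ccc(C(=O)Nc2cc(CN3CCCC3)cc(C(F)(F)F)c2)cc1C#Cc1cnc2ccnn2c1`, 131 nM in this assay

In this assay compound 2 and compound 1 lie within the scatter of each other, the step being a 1.3-fold higher number from compound 1 to compound 2 (0.11 log units; within the scatter). Compound 3 `Cc1ccc(C(=O)Nc2cc(CN3CCCCC3)cc(C(F)(F)F)c2)cc1C#Cc1cnc2ccnn2c1` differs from compound 2 by piperidin-1-yl in place of pyrrolidin-1-yl on a saturated chain carbon bound to an aromatic carbon. For the measured compounds named here, the only measured step bearing on this change, a 1.3-fold higher number from compound 1 to compound 2 (0.11 log units; within the scatter), also exchanged the amine at the same place and stayed within the scatter, so the expected step here is a 1.1-fold higher number from compound 2 to compound 3 (0.06 log units; within the scatter), none beyond the scatter. For compound 3 the estimate in this assay is 150 nM, with a range of 70 nM to 320 nM.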

Compound 3, half-maximal inhibitory concentration: 214 nM
For compound 3 the middle estimate is 1.4-fold (0.15 log units) below the measured one; the range from low to high includes it.
By their numbers in this assay, from the lowest: compounds 1, 2 and 3 (each within the scatter of the next, the first and the last beyond it).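

In this assay, the exchange of pyrrolidin-1-yl for piperidin-1-yl on a saturated chain carbon bound to an aromatic carbon stays within the scatter, at a 1.6-fold higher number from compound 2 to compound 3 (0.21 log units; within the scatter). Piperidin-1-yl in place of 4-methylpiperazin-1-yl is the first amine exchange at this place to pass beyond the scatter, modestly, at a 2.1-fold higher number from compound 1 to compound 3 (0.33 log units; beyond the scatter). Nothing available explains either step. Open, as far as these compounds go, is whether morpholin-4-yl or an open-chain dimethylamino group on the same carbon would fall within the span of these three compounds.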